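This account rests on a few compounds, and the source may have more. Where it says the series, first, only, none or still open, it means among the compounds named here.

Measured in an ADME assay on MT4 cells (Homo sapiens) for cytotoxicity, read by MTT assay, with a stated time of 5 days; on this read-out higher numbers stand for lower toxicity in this test and lower numbers for higher toxicity in this test:
compound 1 `COc1cc(-c2ccc(C#N)cc2)ccc1[C@@H](O)c1ccnc(Nc2ccc(C#N)cc2)n1`: 33100 nM
compound 2 `N#Cc1ccc(Nc2nccc([C@H](O)c3ccc(-c4ccc(C#N)cc4)cc3Cl)n2)cc1`: 28100 nM
compound 3 `Cc1cc(-c2ccc(C#N)cc2)ccc1[C@H](O)c1ccnc(Nc2ccc(C#N)cc2)n1`: 4000 nM

Compound 3 has the lowest number of the three, and its gap to each of the other two lies beyond the scatter. Compound 4 `Cc1cc(-c2ccc(C#N)cc2)ccc1[C@@H](O)c1ccnc(Nc2ccc(C#N)cc2)n1` follows from compound 3 by a single change: the two compounds have the same atoms and bonds and differ only in configuration as drawn: 1 of 1 stereo elements differ; a stereocentre at a saturated chain carbon is drawn S in compound 3 and R in compound 4. For the measured compounds named here, no measured step alters configuration alone, so the size of this change has no direct precedent. Going by the values given here, the one measured step, a 1.2-fold lower number from compound 1 to compound 2 (0.07 log units; within the scatter), exchanges methoxy for chloro and keeps the configuration as drawn. As drawn, compound 4 shares its arrangement at the stereocentre with compounds 1 and 2, whereas compound 3 has the opposite one and also carries methyl instead of methoxy or chloro. The low number of compound 3 could therefore go with either feature, and the data cannot separate them. The expectation leans on compound 1 at 33100 nM and compound 2 at 28100 nM as the values reached with that arrangement, but only part of the way. A rise is thus expected, estimated as a 3.8-fold higher number from compound 3 to compound 4 (0.57 log units; beyond the scatter) in size. Compound 4 is estimated at 15000 nM in this assay, with an expected range from 5000 nM to 40000 nM as its bounds.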

Compound 4, half-maximal cytotoxic concentration: 35600 nM
Compound 4: the middle estimate sits 2.4-fold (0.38 log units) below what was measured; the measured number falls inside the stated range.
By their numbers in this assay, from the lowest: compound 3; then compounds 2, 1 and 4 (each within the scatter of the next).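

In this assay, configuration alone now has a measured step, an 8.9-fold higher number from compound 3 to compound 4 (0.95 log units; beyond the scatter), so the low number of compound 3 goes with its S arrangement as drawn and not with its methyl group alone, as the comparison isolates this one feature: the fact that compounds 3 and 4 differ only in the configuration as drawn

With the R arrangement as drawn, methyl on the aromatic carbon gives a number that cannot be told apart from those given by chloro or methoxy: a 1.3-fold higher number from compound 2 to compound 4 (0.10 log units; within the scatter), and a 1.1-fold higher number from compound 1 to compound 4 (0.03 log units; within the scatter). Compounds 1, 2 and 4 thus all lie within the scatter of one another, and compound 3 is the only one of the four that stands apart in this assay.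

The S arrangement appears here only with methyl, so the compounds shown leave open whether chloro or methoxy would show a similar gap between the two configurations. They also leave open whether the R arrangement would keep its number with a different group on that aromatic carbon, such as an amine, a carboxylic acid or a longer chain.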